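Tolerance Limit Holds Across Aryl Changes on the Shared Core

The compounds below may be only part of what the source reports. "The series", "measured", "known", "first", "only" and "open" are said of these compounds alone.

Measured so far:
Compound 1, `Cc1ccc(-c2nnc(-c3sc(-c4cccnc4)nc3C)o2)cc1`: in an ADME assay on HeLa cells (Homo sapiens) for cytotoxicity, read by MTT assay (a lower number here means that less compound is tolerated, a higher number that more compound is tolerated), compound 1 gives > 100 ug/mL, a limit of the assay.
Compound 2, `COc1ccccc1-c1nnc(-c2sc(-c3cccnc3)nc2C)o1`: in this assay compound 2 gives > 100 ug/mL, a limit of the assay.
Compound 3, `Cc1nc(-c2cccnc2)sc1-c1nnc(-c2ccc(Cl)cc2)o1`: in this assay compound 3 gives > 100 ug/mL, a limit of the assay.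

Compound 3 therefore stands at a limit only, and the two other values shown are limits too; all three sit at the limit of > 100 ug/mL in this assay, at which 3 of the 3 values shown sit. The steps a step that the two limits leave unreadable from compound 1 to compound 2, a step that the two limits leave unreadable from compound 1 to compound 3 and a step that the two limits leave unreadable from compound 2 to compound 3 are accordingly unreadable in size, since each joins two limits.

Compound 4, `Cc1cccc(-c2nnc(-c3sc(-c4cccnc4)nc3C)o2)c1`, differs from compound 3 by 3-methylphenyl in place of 4-chlorophenyl on an aromatic carbon. The step from compound 2 to compound 3 bears most directly on it, as it also swaps one aryl group for another at the same place, and it left the limit untouched; the other two steps did the same. In this assay no step beyond the scatter is therefore expected, and the result is expected to be a limit again. Compound 4 is estimated at 150 ug/mL, with a range from 80 ug/mL to 300 ug/mL. The step that the limit leaves unreadable from compound 3 to compound 4 is expected to be none beyond the scatter.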

Compound 4, half-maximal cytotoxic concentration: > 100 ug/mL
Compound 4: only a limit was reported (the forecaster's own chance of this, stated with the estimate: 85%); the middle value does not contradict the limit.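

Among the compounds shown here, compound 4 stands at a limit, as do compound 1, compound 2 and compound 3, so no step from any of them to compound 4 can be read in this assay: the limit of > 100 ug/mL in this assay, at which 4 of the 4 values shown sit. The compounds shown leave open whether any aryl group on the shared core gives a reading that is not a limit.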